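The source may hold more compounds than are shown below. What is called first, only, known or untested is meant among the compounds shown, and "the series" means these compounds.

Measured so far in a physicochemical assay for metabolic stability, in the presence of a further agent that is not named here; a lower number here means that the compound disappears faster, a higher number that the compound lasts longer:
- compound 1 `Cc1cn([C@H]2C[C@H](SSC(Cl)(Cl)Cl)[C@@H](CO)O2)c(=O)[nH]c1=O`; in this assay compound 1 gives the limit < 1.5 h.
- compound 2 `Cc1cn([C@H]2C[C@H](SSc3ccccc3[N+](=O)[O-])[C@@H](CO)O2)c(=O)[nH]c1=O`; in this assay compound 2 gives the limit < 0.167 h.
- compound 3 `Cc1cn([C@H]2C[C@H](SSc3ccc([N+](=O)[O-])cc3)[C@@H](CO)O2)c(=O)[nH]c1=O`; in this assay compound 3 gives the limit < 0.167 h.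

None of the three values is a number; each is a limit of this assay. Compound 3 stands at the limit of < 0.167 h in this assay, at which 2 of the 3 values shown sit, together with compound 2. Compound 1 stands at the limit of < 1.5 h in this assay, at which 1 of the 3 values shown sits. The measured steps are accordingly unreadable: a step that the two limits leave unreadable from compound 1 to compound 2, a step that the two limits leave unreadable from compound 1 to compound 3 and a step that the two limits leave unreadable from compound 2 to compound 3 give no size and no direction.

The next compound, compound 4 `C=CCSS[C@H]1C[C@H](n2cc(C)c(=O)[nH]c2=O)O[C@@H]1CO`, differs from compound 3 by allyl in place of 4-nitrophenyl on a sulfur. Within the data shown here, no measured step exchanges an aryl group on the disulfide for an allyl group, and the three measured steps carry no readable size, so nothing here fixes the expected size of an at least 5.9-fold higher number from compound 3 to compound 4 (0.77 log units; beyond the scatter); a step of either sign remains possible. For compound 4 the estimate in this assay is 1 h, expected somewhere between 0.1 h and 10 h, with a fair chance that only a limit is again reported.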

Compound 4, half-life: < 8 h
Compound 4 was reported as a limit; the forecaster's own chance of this, stated with the estimate: 50%; the middle value does not contradict the limit.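

In this assay compound 4 gives < 8 h, a limit and not a number, so its steps from compound 1, compound 2 and compound 3 cannot be read. The compounds shown leave open the actual half-life of all four compounds and the direction of any change on the sulfur.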